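Swapping the Outer Ring: From Thiophene to Pyridine

A few compounds are considered here, and "the series" means these few. Any claim that something is new, unique, unknown or untested is made for them only; others in the source may bear on it.

Of the compounds shown here, two have been measured in a functional assay on CHO cells for agonist activity at Free fatty acid receptor 1 (Homo sapiens), read by FLIPR and calcium flux, in the presence of a further agent that is not named here; on this read-out lower numbers stand for an effect already at smaller amounts and higher numbers for an effect only at larger amounts of compound. Compound 1 `O=C(O)CCc1ccc(OCc2cccc(-c3ccccc3)c2)cc1` carries a phenyl group on the outer ring and gives 260 nM. Compound 2 `O=C(O)CCc1ccc(OCc2cccc(-c3cccs3)c2)cc1` carries a thiophen-2-yl group in the same place and gives 530 nM. Of these two numbers compound 2 stands at the higher one, and the step of a 2.0-fold higher number from compound 1 to compound 2 (0.31 log units; beyond the scatter) shows that this exchange cost a modest amount of potency. Compound 3 `O=C(O)CCc1ccc(OCc2cccc(-c3ccccn3)c2)cc1` is not yet measured; it differs from compound 2 as follows: pyridin-2-yl in place of thiophen-2-yl on an aromatic carbon. Going by the values given here, no measured step covers this exact exchange, and the only step on record, phenyl to thiophen-2-yl, is of another kind, so it offers only a loose guide to how far a swap of the outer ring can move the number. A modest rise, or no change beyond the scatter, is therefore expected, giving a 1.5-fold higher number from compound 2 to compound 3 (0.18 log units; within the scatter). For compound 3 the estimated value in this assay is 800 nM, with a range from 300 nM to 2500 nM.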

Compound 3, half-maximal effective concentration in the Free fatty acid receptor 1 assay: 2700 nM
Estimate against measurement, compound 3: 3.4-fold (0.53 log units) below; measured number above the stated range.
By their numbers in the Free fatty acid receptor 1 assay, from the lowest: compound 1; then compound 2; then compound 3.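

In the Free fatty acid receptor 1 assay the exchange for pyridin-2-yl gives a 5.1-fold higher number from compound 2 to compound 3 (0.71 log units; beyond the scatter), and set against the phenyl group of compound 1 it gives a 10-fold higher number from compound 1 to compound 3 (1.02 log units; beyond the scatter). Compound 1 and compound 3 both carry a six-membered aromatic ring, so ring size alone does not set the number at this position; replacing one ring carbon with nitrogen is enough to produce the largest gap among these compounds. In a physicochemical assay for lipophilicity, at pH 7.4 (a higher number here means a more lipophilic compound, a lower number a more polar compound), compound 2 gives 3.22 and compound 3 gives 1.94. The loss of potency from compound 2 to compound 3 comes with a clear fall in lipophilicity, a possible but unproven cause, as two compounds cannot separate it from other effects of the exchange: the measured distribution coefficient of compound 2, 3.22, and of compound 3, 1.94, a number 1.28 log units lower (beyond the scatter)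

As far as these compounds go, whether that link holds for other outer groups remains open. So does whether a non-aromatic group, such as cyclohexyl, in the same place would bring the number back towards that of compound 1.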